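This account rests on a few compounds, and the source may have more. Where it says the series, first, only, none or still open, it means among the compounds named here.

In a functional assay on MDA-MB-231 cells (Homo sapiens) for inhibition, read by sulforhodamine B assay, with a stated time of 72 h (on this read-out higher numbers stand for weaker inhibition of growth and lower numbers for stronger inhibition of growth), compound 1 `CCOC(=O)/C=C/c1ccncc1-c1ccc2c(cnn2C)c1` gives > 10000 nM as a limit of the assay and not a number. Compound 2 `Cn1ncc2cc(-c3cnccc3/C=C/C(=O)O)ccc21` gives > 10000 nM which is also a limit and not a number. Within the data shown here, the only measured step is a step that the two limits leave unreadable from compound 1 to compound 2 and it offers no size to carry forward, while the limit of > 10000 nM in this assay, at which 2 of the 2 values shown sit, is the whole of the evidence. Compound 3 `CNC(=O)/C=C/c1ccncc1-c1ccc2c(cnn2C)c1` differs from compound 2 by methylamino in place of hydroxy on a carbonyl carbon with methylamino in place of hydroxy on a carbonyl carbon. The estimated a number no higher from compound 2 to compound 3 (the limit leaves the size open) stands for no expected move beyond the scatter in this assay in either direction. Compound 3 is expected at about 10000 nM with an estimated range from 3000 nM to 30000 nM and may well be a limit.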

Compound 3, concentration for 50% growth inhibition: > 10000 nM
Compound 3: no number, only a limit; the forecaster's own chance of this, stated with the estimate: 75%; the middle value sits exactly at the limit.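

No step among compound 1, compound 2 and compound 3 can be read, since each gives only a limit and not a number: the limit of > 10000 nM in this assay, at which 3 of the 3 values shown sit.

The compounds shown leave open how strongly any of them inhibits growth in this assay, and whether changing the group on the carbonyl carbon makes any difference.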